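Swapping the propoxy group for dimethylamino on the shared core

The compounds below may be only part of what the source reports. "The series", "measured", "known", "first", "only" and "open" are said of these compounds alone.

Measured so far:
- compound 1, `CCCOc1ccc(-c2nc3cc(C(F)(F)F)ccc3[nH]2)cc1`, 19%
- compound 2, `COc1ccccc1-c1nc2cc(C(F)(F)F)ccc2[nH]1`, 45.7%
- compound 3, `CCOc1ccccc1-c1nc2cc(C(F)(F)F)ccc2[nH]1`, 19.8%

All three compounds were tested in a functional assay on aorta (Rattus norvegicus, strain Wistar) for inhibition, with a stated time of 60 min; a lower number here means a smaller maximal response, a higher number a larger maximal response. Compound 1 gives the lowest of the three numbers. Its nearest neighbour is compound 3, whose value lies within the scatter of that of compound 1, so the two cannot be told apart. Compound 2 stands clearly higher. Within the data shown here, the one step that can be read between measured compounds is a number 25.9 percentage points lower from compound 2 to compound 3 (beyond the scatter), a modest fall.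

Compound 4, `CN(C)c1ccc(-c2nc3cc(C(F)(F)F)ccc3[nH]2)cc1`, has not yet been measured. It differs from compound 1 in one place: dimethylamino in place of propoxy on an aromatic carbon.

Among the measured compounds shown here, no measured step touches this position; the only step, between compound 2 and compound 3, concerns an alkoxy group placed differently on the same ring. For the measured compounds named here, it shows only that a change on that ring can move the response by a modest amount. With nothing pointing in either direction, the expectation is that compound 4 stays near compound 1, with a step of a number 5 percentage points higher from compound 1 to compound 4 (within the scatter) that is estimated as not beyond the scatter. The value expected for compound 4 in this assay is 24%, estimated between 10% and 45%.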

Compound 4, largest response reached (Emax), in percent of the reference or control that the assay uses: 30.9%
Beside the measured number, compound 4's estimate is 6.9 percentage points below it; low and high end bracket the measured number.
By their numbers in this assay, from the lowest: compounds 1 and 3 (each within the scatter of the next); then compound 4; then compound 2.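

In this assay, among these compounds, the step of a number 11.9 percentage points higher from compound 1 to compound 4 (beyond the scatter) gives the first direct reading at this position, on an aromatic carbon para to a large group, and it shows that the response here does change with the group attached. Among the compounds shown here, the only earlier step concerned an alkoxy group placed differently on the ring, so it could not show this. The counted features do not separate the two groups, since propoxy and dimethylamino each have no ring, no net charge and the same hydrogen-bond donor and acceptor counts, and nothing measured here explains the rise, so it stands as an observation without a known cause.

The compounds shown leave open whether the change follows from the nitrogen that links dimethylamino to the ring or from the alkyl groups it carries, a question that a plain amino group or a diethylamino group at the same place could help answer. On these data alone, it also remains open how a group of another kind, such as a carboxylic acid or a morpholine ring, would fare on this carbon.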